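From hydroxy to nitro on a shared core

The source may report more compounds than this note shows. Statements on the series, on what has been measured and on what is new or still open speak of the compounds shown alone.

Measured in a functional assay on HT-29 cells (Homo sapiens) for inhibition, read by MTT assay; a lower number here means a stronger inhibitor, a higher number a weaker inhibitor:
Compound 1 `COc1ccc(/C=C2\c3cc(OC)c(OC)c(OC)c3CC[C@@H]2O)cc1C#N`: 5 nM
Compound 2 `COc1ccc(/C=C2\c3cc(OC)c(OC)c(OC)c3CC[C@@H]2O)cc1O`: 260 nM

Within the data shown here, compound 2 has the higher number of the pair, and compound 1 is its only neighbour. Compound 3 `COc1ccc(/C=C2\c3cc(OC)c(OC)c(OC)c3CC[C@@H]2O)cc1[N+](=O)[O-]` has not yet been measured in this assay. It carries nitro in place of hydroxy on an aromatic carbon, ortho to a methoxy group (2 heavy atoms) and meta to a large group: nitro in place of hydroxy on an aromatic carbon.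

Among the measured compounds shown here, only one measured step bears on this change. It puts hydroxy in place of cyano on an aromatic carbon and is large: a 52-fold higher number from compound 1 to compound 2 (1.72 log units; beyond the scatter). Hydroxy is thus the poorer of the two groups measured, but nitro itself is untested, so a smaller step towards a lower number is expected. The expected step is a 7.4-fold lower number from compound 2 to compound 3 (0.87 log units; beyond the scatter). Compound 3 is estimated at 35 nM, with an expected range of 6 nM to 200 nM.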

Compound 3, half-maximal inhibitory concentration: 1590 nM
For compound 3 the middle estimate is 45-fold (1.66 log units) below the measured one; measured number outside the range, above it.
By their numbers in this assay, from the lowest: compound 1; then compound 2; then compound 3.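

In this assay there is a 6.1-fold higher number from compound 2 to compound 3 (0.79 log units; beyond the scatter) and this shows that hydroxy is not the poorest group tried on this aromatic carbon, ortho to a methoxy group. Taking hydroxy away does not by itself lower the number, so the outcome depends on which group enters. There is also a 320-fold higher number from compound 1 to compound 3 (2.50 log units; beyond the scatter) and this is the widest gap among the three compounds, so the position separates cyano from nitro far more sharply than the first pair could show.

Nothing measured here accounts for this order of the three groups. As far as these compounds go, it remains open where an amine, a carboxylic acid or a halogen such as chlorine on this carbon would fall relative to cyano and nitro, and whether any group would give a lower number than cyano.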